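A few compounds are considered here, and "the series" means these few. Any claim that something is new, unique, unknown or untested is made for them only; others in the source may bear on it.

Compound 3 `CCCCN(CC1CCCN1C)c1cc(C)nc2c(-c3ccc(Cl)cc3Cl)nn(C)c12` sits at the top of the three numbers measured in an assay on HEK293 cells for displacement of a labelled ligand from corticotropin-releasing factor receptor 1 (Homo sapiens); a higher number here means a weaker inhibitor, a lower number a stronger inhibitor: compound 3 gives 380 nM. Its neighbours are compound 1 `CCCCNc1cc(C)nc2c(-c3ccc(Cl)cc3Cl)nn(C)c12`, which in this assay gives 170 nM, and compound 2 `CCCCN(CCCOC)c1cc(C)nc2c(-c3ccc(Cl)cc3Cl)nn(C)c12`, which gives 18 nM. The two steps that reach compound 3 both climb: a 2.2-fold higher number from compound 1 to compound 3 (0.35 log units; beyond the scatter) and a 21-fold higher number from compound 2 to compound 3 (1.32 log units; beyond the scatter). The step to compound 4 `CCCCN(Cc1ccncc1)c1cc(C)nc2c(-c3ccc(Cl)cc3Cl)nn(C)c12` takes away the group that carried those climbs, (pyridin-4-yl in place of 1-methylpyrrolidin-2-yl on a saturated chain carbon bound to a nitrogen on an aromatic ring). Going by the values given here, no measured pair exchanges the 1-methylpyrrolidin-2-yl for an aromatic ring, so the bearing steps are only those two; the larger of them, from compound 2, shows how far the number can move when that group is swapped, and even the hydrogen of compound 1 gave a lower number. He therefore expects compound 4 to return at least part of the way and estimates a modest to large fall, a 6.3-fold lower number from compound 3 to compound 4 (0.80 log units; beyond the scatter), landing at 60 nM with a range from 15 nM to 250 nM.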

Compound 4, inhibition constant: 68 nM
Compound 4: middle estimate off by 1.1-fold (0.05 log units), on the low side; measured number inside the range.
By their numbers in this assay, from the lowest: compound 2; then compound 4; then compound 1; then compound 3.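

In this assay, pyridin-4-yl in place of 1-methylpyrrolidin-2-yl gives a 5.6-fold lower number from compound 3 to compound 4 (0.75 log units; beyond the scatter), so the identity of the ring on this saturated chain carbon moves the number even though the heavy-atom count stays the same. A ring-bearing group on this nitrogen can also improve on hydrogen: (pyridin-4-yl)methyl gives a 2.5-fold lower number from compound 1 to compound 4 (0.40 log units; beyond the scatter), whereas compound 3 stood above compound 1, yet pyridin-4-yl in place of 2-methoxyethyl still gives a 3.8-fold higher number from compound 2 to compound 4 (0.58 log units; beyond the scatter), leaving compound 2 with the lowest number of the four. Nothing available explains why these groups differ.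

On these data alone, whether the lower number follows the aromatic ring itself or its ring nitrogen stays open, and a plain phenyl on the same chain carbon would separate the two. As far as these compounds go, it is equally open how a pyrrolidin-2-yl lacking the methyl group would compare.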